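Sulfonamide aryl variation on the shared enone series

This account rests on a few compounds, and the source may have more. Where it says the series, first, only, none or still open, it means among the compounds named here.

Compound 2 `O=C(/C=C/c1cccc(NS(=O)(=O)c2ccccc2Cl)c1)c1nc2ccccc2[nH]1` gives 987 nM in a functional assay on HCT-116 cells (Homo sapiens) for antiproliferative activity, read by MTT assay, with a stated time of 48 h (a lower number here means a stronger inhibitor, a higher number a weaker inhibitor), the lower of the two numbers shown, though compound 1 `O=C(Nc1cccc(/C=C/C(=O)c2nc3ccccc3[nH]2)c1)c1cccc(Cl)c1` gives 1120 nM and the step of a 1.1-fold lower number from compound 1 to compound 2 (0.05 log units; within the scatter) is within the scatter. Compound 3 `Cc1ccc(S(=O)(=O)Nc2cccc(/C=C/C(=O)c3nc4ccccc4[nH]3)c2)cc1` carries 4-methylphenyl in place of 2-chlorophenyl on a sulfonyl sulfur. Among the measured compounds shown here, the only measured step, a 1.1-fold lower number from compound 1 to compound 2 (0.05 log units; within the scatter), alters the linker on the ring nitrogen rather than the aryl group on the sulfonyl sulfur, so nothing measured bears directly on this change. For this assay the expected step of a 1.0-fold higher number from compound 2 to compound 3 (0.01 log units; within the scatter) is none beyond the scatter. Compound 3 is therefore estimated at 1000 nM, range 400 nM to 2500 nM.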

Compound 3, half-maximal inhibitory concentration: 1990 nM
For compound 3 the middle estimate is 2.0-fold (0.30 log units) below the measured one; the measured number falls inside the stated range.
By their numbers in this assay, from the lowest: compounds 2, 1 and 3 (each within the scatter of the next).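

Among the compounds shown here, replacing 2-chlorophenyl with 4-methylphenyl on a sulfonyl sulfur in this assay gives a 2.0-fold higher number from compound 2 to compound 3 (0.30 log units; within the scatter) and is the first reading of the aryl group at this position, so the two aryl groups are not separated here. Against the amide-linked compound, the (4-methylphenyl)sulfonyl group gives a 1.8-fold higher number from compound 1 to compound 3 (0.25 log units; within the scatter) and again shows no separation. No supporting measurement accounts for either step.

Going by these compounds, whether a pyridine ring, a phenyl ring bearing an amine or carboxylic acid, or a longer alkyl chain on the sulfonyl sulfur would move the number beyond the scatter remains open.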